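A few compounds are considered here, and "the series" means these few. Any claim that something is new, unique, unknown or untested is made for them only; others in the source may bear on it.

Compound 1 `Cc1cc(NC(=O)Nc2cccc(C(N)=O)c2)c2ccccc2n1` was tested in an ADME assay on HEK293 cells (Homo sapiens) for cytotoxicity, with a stated time of 72 h (a lower number here means that less compound is needed, a higher number that more compound is needed for the effect), where compound 1 gives > 25000 nM, a limit of the assay rather than a number. Compound 3 `Cc1cc(NC(=O)Nc2cccc3nsnc23)c2ccccc2n1` likewise reaches only a limit in this assay, > 25000 nM. Compound 2 `Cc1cc(NC(=O)Nc2ccc(Cl)cc2Cl)c2ccccc2n1` gives 10000 nM in this assay. Compound 1 thus sits at the limit of > 25000 nM in this assay, at which 2 of the 3 values shown sit, with no measured number to place it against compound 2 or compound 3. Compound 4 `Cc1cc(NC(=O)Nc2cccc(N(C)C)c2)c2ccccc2n1` differs from compound 1 in one place: dimethylamino in place of carbamoyl on an aromatic carbon. Among the measured compounds shown here, no measured pair of compounds spans this change, so the size of the step can only be estimated. The step expected is an at least 1.2-fold lower number from compound 1 to compound 4 (0.09 log units; that floor lies within the scatter), within the scatter rather than beyond it. Compound 4 is expected to give 20000 nM in this assay, between 8000 nM and 50000 nM.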

Compound 4, half-maximal effective concentration: > 25000 nM
Compound 4 ended at the assay's limit; the forecaster's own chance of this, stated with the estimate: 55%; middle value at least 1.2-fold (0.09 log units) away from the limit.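

Compound 4 stands at the same assay limit as compound 1, so the step between them cannot be read: the limit of > 25000 nM in this assay, at which 3 of the 4 values shown sit. Left open is whether dimethylamino in place of carbamoyl changes the number in this assay at all.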